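A few compounds are considered here, and "the series" means these few. Any claim that something is new, unique, unknown or untested is made for them only; others in the source may bear on it.

Compound 1 `Cc1ccc(-n2nc(-c3ccc(C(F)(F)F)cc3O)nc2-c2ccccc2O)cc1` gives 94.1% in a functional assay on PC-12 cells (Rattus norvegicus) for cytotoxicity, read by MTT assay, with stated times of 2 h and 24 h, tested at 5 uM; a lower number here means a weaker effect, a higher number a stronger effect of the compound at the concentration tested. It has the highest of the three numbers, yet compound 3 `Oc1cc(C(F)(F)F)ccc1-c1nc(-c2ccccc2O)n(-c2cccc(Cl)c2)n1` with 92.7% and compound 2 `N#Cc1ccc(-n2nc(-c3ccc(C(F)(F)F)cc3O)nc2-c2ccccc2O)cc1` with 86.8% both lie within the scatter of it. The step of a number 1.4 percentage points lower from compound 1 to compound 3 (within the scatter) and the step of a number 5.9 percentage points higher from compound 2 to compound 3 (within the scatter) both swapped the group on the aromatic nitrogen without a change beyond the scatter, and the step of a number 7.3 percentage points lower from compound 1 to compound 2 (within the scatter) was small too.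

Compound 4 `Oc1cc(C(F)(F)F)ccc1-c1nc(-c2ccccc2O)n(-c2cc(F)cc(F)c2)n1` differs from compound 1 by 3,5-difluorophenyl in place of 4-methylphenyl on an aromatic nitrogen. Since the related swaps on the aromatic nitrogen moved nothing beyond the scatter, compound 4 is expected to show a step of a number 2.1 percentage points lower from compound 1 to compound 4 (within the scatter), no more than the scatter. Compound 4 is therefore estimated at 92%, within 80% to 98%.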

Compound 4, a percentage reported as activity, at one concentration (the size of the read-out at that concentration, not a potency): 100%
For compound 4 the middle estimate is 8 percentage points below the measured one; measured number outside the range, above it.
By their numbers in this assay, from the lowest: compounds 2, 3, 1 and 4 (each within the scatter of the next, the first and the last beyond it).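

In this assay, for the compounds shown here, the step of a number 13.2 percentage points higher from compound 2 to compound 4 (beyond the scatter) is the first swap on this aromatic nitrogen to pass the scatter, so the group there can matter, though only modestly. Both a number 5.9 percentage points higher from compound 1 to compound 4 (within the scatter) and a number 7.3 percentage points higher from compound 3 to compound 4 (within the scatter) stay inside the scatter, so 3,5-difluorophenyl separates only from 4-cyanophenyl. Nothing available explains this difference.

All four groups at this position are substituted phenyl rings. Going by these compounds, what an amine, a carboxylic acid or a longer alkyl chain would do there remains open.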